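The source may report more compounds than this note shows. Statements on the series, on what has been measured and on what is new or still open speak of the compounds shown alone.

Measured so far:
- Compound 1 `O=S(=O)(/C=C/c1ccc(F)cc1)Cc1ccc(Nc2ncnc3ccccc23)cc1`: 100000 nM
- Compound 2 `O=S(=O)(/C=C/c1ccc(O)cc1)Cc1ccc(Nc2ncnc3ccccc23)cc1`: 100000 nM

In a functional assay on SW-620 cells (Homo sapiens) (a lower number here means a stronger inhibitor of growth, a higher number a weaker inhibitor of growth), compound 2 gives 100000 nM, level with compound 1 at 100000 nM. Going by the values given here, only one measured step exists, and it put hydroxy in place of fluoro on an aromatic carbon: no change at the digits printed from compound 1 to compound 2 (within the scatter). Compound 3 `O=S(=O)(/C=C/c1ccc(O)cc1)Cc1ccc(Nc2ncnc3ccc(Br)cc23)cc1` keeps all of compound 2 except for one change to the shared core, bromo in place of hydrogen on an aromatic carbon. Among the compounds with values here, the measured step offers only weak guidance, as it concerns a different group, and no measured compound carries bromo. It gives no sign that a single swap must shift the number, yet it cannot rule out a shift at a new place. A modest move toward stronger inhibition is therefore expected, with the estimated step being a 2.5-fold lower number from compound 2 to compound 3 (0.40 log units; beyond the scatter). For compound 3 the estimate is 40000 nM, with an expected range of 5000 nM to 100000 nM.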

Compound 3, concentration for 50% growth inhibition: 94000 nM
Beside the measured number, compound 3's estimate is 2.4-fold (0.37 log units) below it; measured number inside the range.
By their numbers in this assay, from the lowest: compounds 3, 1 and 2 (each within the scatter of the next).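

In this assay, bromo in place of hydrogen on the shared core gives a 1.1-fold lower number from compound 2 to compound 3 (0.03 log units; within the scatter). Going by these compounds alone, the earlier step changed only a fluoro to a hydroxy on a different aromatic ring, so this is the first sign that a change on the core, at this carbon of its six-membered aromatic ring of carbon only, can also leave the growth-inhibition number unmoved, at least when the group added is a single bromine atom in compound 2. Nothing measured here explains why the number holds steady.

From the compounds shown here alone, whether a different group at this same carbon, such as an amine, a carboxylic acid or a methoxy, would shift the number remains open. Also open, going by these compounds, is whether bromo would have any effect in a compound with an amine in place of the hydroxy.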